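From a sulfonamide to a nitrobenzamide on the shared core

A few compounds are considered here, and "the series" means these few. Any claim that something is new, unique, unknown or untested is made for them only; others in the source may bear on it.

Measured compounds:
compound 1 `COc1ccc(S(=O)(=O)Nc2ccc(-c3nc4cc(NS(=O)(=O)c5ccc(OC)cc5)ccc4o3)cc2)cc1`: > 100000 nM
compound 2 `O=S(=O)(Nc1ccc(-c2nc3cc(NS(=O)(=O)c4ccccc4Cl)ccc3o2)cc1)c1ccccc1Cl`: > 100000 nM

In an assay on isolated protein for inhibition of thiosulfate sulfurtransferase (Homo sapiens) (a higher number here means a weaker inhibitor, a lower number a stronger inhibitor), compound 1 gives > 100000 nM, which is a limit of the assay and not a number. Compound 2 gives > 100000 nM in this assay, again only a limit. Compound 1 therefore stands where every value shown stands, at the limit (the limit of > 100000 nM in this assay, at which 2 of the 2 values shown sit). Compound 3 `COc1ccc(S(=O)(=O)Nc2ccc3oc(-c4ccc(NC(=O)c5cccc(C)c5[N+](=O)[O-])cc4)nc3c2)cc1` has not yet been measured in this assay. It differs from compound 1 in one place: (3-methyl-2-nitrophenyl)carbonyl in place of (4-methoxyphenyl)sulfonyl on a nitrogen on an aromatic ring. Going by the values given here, no step between measured compounds is known, so the size of this change cannot be read from the numbers. The step is expected to be an at least 2.0-fold lower number from compound 1 to compound 3 (0.30 log units; that floor lies within the scatter), if anything toward a stronger inhibitor, since only a limit is known for the starting point. Compound 3 is estimated at 50000 nM, with a range from 5000 nM to 200000 nM.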

Compound 3, half-maximal inhibitory concentration: > 100000 nM
Compound 3 was reported as a limit (the forecaster's own chance of this, stated with the estimate: 55%); middle value at least 2.0-fold (0.30 log units) away from the limit.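

Compound 1 and compound 3 both stand at a limit in this assay, so the step between them cannot be read: the limit of > 100000 nM in this assay, at which 3 of the 3 values shown sit.

The compounds shown leave open whether any change on the shared core gives a measurable value in this assay.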